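The source may hold more compounds than are shown below. What is called first, only, known or untested is meant among the compounds shown, and "the series" means these compounds.

Of the compounds shown here, two have numbers so far in a functional assay on PC-3 cells (Homo sapiens) for cytotoxicity, read by MTT assay, with a stated time of 72 h; on this read-out lower numbers stand for stronger inhibition and higher numbers for weaker inhibition. Compound 1 `Cc1cc(=O)n(-c2cccc(F)c2)nc1C(=O)Nc1ccc(Oc2ncnc3[nH]ccc23)cc1` gives 14600 nM in this assay. Compound 2 `Cc1cc(=O)n(-c2ccc(Br)cc2F)nc1C(=O)Nc1ccc(Oc2ncnc3c2ccn3C)cc1` gives 18800 nM in this assay, the highest of the two numbers, but its gap to compound 1 lies within the scatter, so the two cannot be ordered against each other. Compound 3 `Cc1cc(=O)n(-c2cccc(F)c2)nc1C(=O)Nc1ccc(Oc2ncnc3c2ccn3C)cc1` has not been measured. It differs from compound 2 in one place: 3-fluorophenyl in place of 4-bromo-2-fluorophenyl on an aromatic nitrogen. Compound 3 thus carries the same 3-fluorophenyl as compound 1 on the core of compound 2. Going by the values given here, no step between measured compounds is available to size this exchange, so the expectation rests on the two values alone. The step of a 1.3-fold lower number from compound 2 to compound 3 (0.10 log units; within the scatter) is expected to be small and not beyond the scatter, because compound 1 with the same 3-fluorophenyl gives 14600 nM and compound 2 gives 18800 nM in this assay. For compound 3 the estimate in this assay is 15000 nM, with a range from 6000 nM to 40000 nM.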

Compound 3, half-maximal inhibitory concentration: > 60000 nM
Compound 3: only a limit was reported (the forecaster's own chance of this, stated with the estimate: 10%); at least 4.0-fold (0.60 log units) between middle value and limit.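

In this assay compound 3 is known only as a limit: the limit of > 60000 nM in this assay, at which 1 of the 3 values shown sits. On the aromatic nitrogen of the shared core, 3-fluorophenyl in place of 4-bromo-2-fluorophenyl gives an at least 3.1-fold higher number from compound 2 to compound 3 (0.50 log units; beyond the scatter), so this position is not indifferent to the aryl group it carries, which the earlier pair could not show. With the 3-fluorophenyl held fixed, methyl in place of hydrogen on an aromatic nitrogen of the core gives an at least 4.1-fold higher number from compound 1 to compound 3 (0.61 log units; beyond the scatter), so the two earlier values that could not be ordered against each other conceal two single changes that run in opposite directions.

From the compounds shown here alone, the full size of both steps stays open, and the exchange on the aryl group does not separate the bromine from the different placing of the fluorine. Whether a 4-bromophenyl or a 2-fluorophenyl on the same nitrogen would match the number of compound 2, and whether an ethyl on the core nitrogen would behave as the methyl does, remains to be seen.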